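Chloro to bromo on the pendant aryl ring

The source may report more compounds than this note shows. Statements on the series, on what has been measured and on what is new or still open speak of the compounds shown alone.

Of the compounds shown here, two have numbers so far. Compound 1 `Cc1ccc2c(Cc3nn4cc(-c5ccc(Br)cc5)nc4s3)coc2c1` carries a 4-bromophenyl group and, in a functional assay on the whole organism (strain Wistar albino) for inhibition, with Rattus norvegicus as the target, read by paw edema, with a stated time of 2 h, at a dose of 100 mg/kg by the oral route (on this read-out higher numbers stand for more inhibition at the one dose given (going by the name of the read-out) and lower numbers for less inhibition), compound 1 gives 12%. Compound 2 `Cc1ccc2c(Cc3nn4c(C=O)c(-c5ccc(Cl)cc5)nc4s3)coc2c1` carries a 4-chlorophenyl group together with a carbonyl on the core, and in this assay compound 2 gives 24.3%, the higher of the two numbers, a gap to compound 1 that lies beyond the scatter. Compounds 1 and 2 differ in two places, so no single step can be read from them.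

Compound 3 `Cc1ccc2c(Cc3nn4c(C=O)c(-c5ccc(Br)cc5)nc4s3)coc2c1`, not yet measured, keeps the carbonyl of compound 2 and differs from it only at the halogen: bromo in place of chloro on an aromatic carbon. Among the measured compounds shown here, with no measured pair showing this exchange, the step in this assay from compound 2 to compound 3 is expected to be small, with no clear direction, and to fall within the scatter, that is a number 0.3 percentage points lower from compound 2 to compound 3 (within the scatter). For compound 3 the estimate in this assay is therefore 24%, within a range from 12% to 36%.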

Compound 3, a percentage reported as inhibition, in the whole organism at one dose (the size of the read-out at that dose, not a potency): 11.2%
Compound 3: the middle estimate sits 12.8 percentage points above what was measured; measured number outside the range, below it.
By their numbers in this assay, from the lowest: compounds 3 and 1 (each within the scatter of the next); then compound 2.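

In this assay the halogen on the aromatic carbon is not a silent place in the series: with the formyl group present, bromo in place of chloro gives a number 13.1 percentage points lower from compound 2 to compound 3 (beyond the scatter) and so marks the 4-chlorophenyl to 4-bromophenyl exchange as a step that can be read at this dose. Among the compounds shown here, with bromo held constant, formyl in place of hydrogen gives a number 0.8 percentage points lower from compound 1 to compound 3 (within the scatter) on the same read-out, so adding the formyl group to the bromo compound does not by itself separate the two numbers, and the only value standing apart among the three belongs to the chloro compound carrying formyl. Nothing at hand bears on why the halogen exchange moves the number.

From the compounds shown here alone, whether the step from chloro to bromo keeps its size on the core without the formyl group stays open, since only the bromo member of that pair has a number here. Also open, going by these compounds, is how the aromatic carbon behaves with other groups in place of the halogen, such as methoxy, an amine or a nitrile, and how the core behaves with a carboxylic acid or a hydroxymethyl group in place of formyl.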